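This account rests on a few compounds, and the source may have more. Where it says the series, first, only, none or still open, it means among the compounds named here.

Three measured compounds open this set, and all three were tested in a functional assay on HCT-116 cells (Homo sapiens) for cytotoxicity, read by MTT assay, with a stated time of 72 h; a lower number here means a stronger inhibitor, a higher number a weaker inhibitor. Compound 1 (`CC1=C(CC[C@@H](C)C(=O)CCC2=CC(=O)OC2)C(C)(C)CCC1`) gave a value recorded only as a limit, < 5 ug/mL. For compound 2 (`C[C@@H]1C[C@@H](O)[C@H]2C(C)(C)CCC[C@]2(C)[C@@]1(O)CCC1=CC(=O)OC1`) the reading is again a limit, < 5 ug/mL. Compound 3 (`C[C@@H]1C[C@@H](O)[C@H]2C(C)(C)CCC[C@]2(C)[C@@]12CC[C@]1(COC(=O)C1)O2`), the starting point of the step followed here, likewise returned only a limit, < 5 ug/mL. Because all three readings sit at the limit of < 5 ug/mL in this assay, at which 3 of the 3 values shown sit, the numbers cannot say which of the three is the stronger inhibitor; each is simply a limit rather than a measured number.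

Compound 4 (`CC(=O)O[C@@H]1C[C@@H](C)[C@]2(CC[C@]3(COC(=O)C3)O2)[C@@]2(C)CCCC(C)(C)[C@H]12`) has not yet been measured. It differs from compound 3 in a single place: acetyl in place of hydrogen on an oxygen on a saturated carbon, which, read one bond further out, is a hydroxy turned into an acetoxy.

For the measured compounds named here, no measured pair in this set differs in just one place, so there is no measured step to lean on. With compound 3 and its two companions all resting at the limit, the step from compound 3 to compound 4 is expected to be a step that the limit leaves unreadable from compound 3 to compound 4, nothing beyond the scatter. Compound 4 is therefore estimated at 3 ug/mL, with a range from 1 ug/mL to 10 ug/mL, and the most likely outcome is that this assay again reports only a limit.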

Compound 4, half-maximal inhibitory concentration: < 5 ug/mL
Compound 4: a limit, no number (the forecaster's own chance of this, stated with the estimate: 70%); the middle value does not contradict the limit.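

In this assay compound 4 gives < 5 ug/mL, which is a limit and not a number. No step from compound 3 to compound 4 can be read, because both compounds rest at the same limit: the limit of < 5 ug/mL in this assay, at which 4 of the 4 values shown sit.

The compounds shown leave open how strong each inhibitor really is, and whether turning the hydroxy into an acetoxy changes cytotoxicity at all.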